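A few compounds are considered here, and "the series" means these few. Any claim that something is new, unique, unknown or untested is made for them only; others in the source may bear on it.

Compound 1, `C#CCNCc1cn(-c2cc(NC(=S)NCC)ncn2)cn1`, gives 5240 nM in an assay on isolated protein for inhibition of Amine oxidase [flavin-containing] B (Homo sapiens), read by fluorescence and Amplex Red, with a stated time of 15 min; on this read-out lower numbers stand for stronger inhibition and higher numbers for weaker inhibition. Compound 2, `C#CCN(CCC)Cc1cn(-c2cc(NC(=S)NCC)ncn2)cn1`, carries a propyl group on the amine nitrogen where compound 1 has hydrogen. For compound 2 the read-out in this assay is a limit of > 50000 nM and not a number. Compound 3, `C#CCN(CCCC)Cc1cn(-c2cc(NC(=S)NCC)ncn2)cn1`, carries a butyl group on that amine nitrogen. For compound 3 the read-out in this assay is likewise a limit of > 50000 nM. The two measured steps read an at least 9.5-fold higher number from compound 1 to compound 2 (0.97 log units; beyond the scatter) and an at least 9.5-fold higher number from compound 1 to compound 3 (0.97 log units; beyond the scatter), so either alkyl group on the amine nitrogen weakens inhibition clearly. The step that the two limits leave unreadable from compound 2 to compound 3 cannot be sized because of the limit of > 50000 nM in this assay, at which 2 of the 3 values shown sit. Compound 3 thus stands at the weak end of what has been measured. Compound 4, `C#CCN(Cc1ccccc1)Cc1cn(-c2cc(NC(=S)NCC)ncn2)cn1`, differs from compound 3 by phenyl in place of propyl on a saturated chain carbon bound to an amine nitrogen. This is a third substituent on the same nitrogen; both earlier ones lost inhibition, and nothing measured tells how an aromatic ring would behave differently from a chain. Compound 4 is therefore expected to remain weak, with an estimated step of an at least 1.2-fold lower number from compound 3 to compound 4 (0.09 log units; that floor lies within the scatter). The estimate for compound 4 is 40000 nM, within 8000 nM to 200000 nM.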

Compound 4, half-maximal inhibitory concentration: > 50000 nM
Compound 4: only a limit was reported; the forecaster's own chance of this, stated with the estimate: 60%; at least 1.2-fold (0.09 log units) between middle value and limit.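

Benzyl, which brings an aromatic ring, does no better in this assay than the two plain chains: putting it in place of hydrogen on the amine nitrogen gives an at least 9.5-fold higher number from compound 1 to compound 4 (0.97 log units; beyond the scatter). The loss of inhibition seen with propyl and butyl therefore also appears with a ring, and among the compounds shown, only compound 1, with hydrogen on that nitrogen, gives a number rather than a limit. The steps among compound 2, compound 3 and compound 4 cannot be read because each of these compounds gives only a limit: the limit of > 50000 nM in this assay, at which 3 of the 4 values shown sit.

Going by these compounds, it remains open whether methyl or ethyl on that nitrogen would keep the inhibition of compound 1 or lose it. Also open, on these data alone, is whether a benzyl group carrying a hydroxyl or an amine would behave differently from plain benzyl.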